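From Acetyl to Cyclobutylcarbonyl on a Shared Core

The source may hold more compounds than are shown below. What is called first, only, known or untested is meant among the compounds shown, and "the series" means these compounds.

Among the compounds with values here, compound 1 `COc1ccc(N)c(C(=O)CCNC(C)=O)c1` is the only compound with a number in hand: in a functional assay for inhibition of kynurenine 3-monooxygenase (Rattus norvegicus), tested at 1 mM (a lower number here means less inhibition, a higher number more inhibition at the concentration tested (going by the name of the read-out)), compound 1 gives 102%. A second compound, compound 2 `Nc1ccc(Cl)cc1C(=O)CCNC(=O)C1CC1`, has no number in this assay; for compound 2 the entry reads "not determined" (no result reported). Compound 3 `COc1ccc(N)c(C(=O)CCNC(=O)C2CCC2)c1` differs from compound 1 in one place, (cyclobutyl in place of methyl on a carbonyl carbon). Within the data shown here, no step between measured compounds is available to calibrate a change of this kind. Because compound 1 already gives 102%, compound 3 is expected to move only within the scatter, a number 6 percentage points lower from compound 1 to compound 3 (within the scatter). Compound 3 is accordingly estimated at 96%, between 80% and 106%.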

Compound 3, a percentage reported as inhibition, at one concentration (the size of the read-out at that concentration, not a potency): 92.2%
Estimate against measurement, compound 3: 3.8 percentage points above, and the stated range covers the measured number.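

In this assay, cyclobutyl in place of methyl on a carbonyl carbon gives a number 9.8 percentage points lower from compound 1 to compound 3 (within the scatter). This position therefore takes a four-membered carbon ring of 4 heavy atoms in place of a single methyl carbon without a change beyond the scatter, though the read-out comes from one concentration and is not a potency. No measurement on hand bears on the reason for this result. The compounds shown leave open how a longer carbon chain, an amine or a carboxylic acid would read at this carbonyl carbon.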